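Alkynyl series at the shared core: pyridinyl to trifluoromethylphenyl

This account rests on a few compounds, and the source may have more. Where it says the series, first, only, none or still open, it means among the compounds named here.

Three measured compounds share one core and differ only in the group on the triple-bonded carbon. Compound 1 `CONc1nc(C#CCCCC#N)nc2c1ncn2[C@@H]1O[C@H](CO)[C@@H](O)[C@H]1O` carries 3-cyanopropyl there, and in an assay on CHO cells for displacement of a labelled ligand from adenosine receptor A3 (Homo sapiens) (a lower number here means a stronger inhibitor, a higher number a weaker inhibitor), compound 1 gives 4.1 nM. Compound 2 `CONc1nc(C#CCC(C)O)nc2c1ncn2[C@@H]1O[C@H](CO)[C@@H](O)[C@H]1O` carries 2-hydroxypropyl; in this assay compound 2 gives 5.4 nM. Compound 3 `CONc1nc(C#Cc2cccnc2)nc2c1ncn2[C@@H]1O[C@H](CO)[C@@H](O)[C@H]1O` carries pyridin-3-yl; in this assay compound 3 gives 7.9 nM. Compound 3 holds the highest of the three numbers, yet its distances to the other two fall within the scatter, as does the gap between the two chain compounds: a 1.3-fold higher number from compound 1 to compound 2 (0.12 log units; within the scatter).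

Compound 4 `CONc1nc(C#Cc2cccc(C(F)(F)F)c2)nc2c1ncn2[C@@H]1O[C@H](CO)[C@@H](O)[C@H]1O` differs from compound 3 in one place: 3-(trifluoromethyl)phenyl in place of pyridin-3-yl on a triple-bonded carbon. Going by the values given here, no measured step exchanges one aromatic ring for another on the triple-bonded carbon. Among the compounds with values here, the steps that bear on the change are the two that brought an aromatic ring in place of a saturated chain, a 1.9-fold higher number from compound 1 to compound 3 (0.28 log units; within the scatter) and a 1.5-fold higher number from compound 2 to compound 3 (0.17 log units; within the scatter), both within the scatter. Three different groups on this carbon thus leave the number in a narrow band. For compound 4 the expected step is accordingly none beyond the scatter, a 1.0-fold higher number from compound 3 to compound 4 (0.01 log units; within the scatter). Compound 4 is estimated at 8 nM, with a range from 3 nM to 25 nM.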

Compound 4, inhibition constant: 23 nM
For compound 4 the middle estimate is 2.9-fold (0.46 log units) below the measured one; measured number inside the range.
By their numbers in this assay, from the lowest: compounds 1, 2 and 3 (each within the scatter of the next); then compound 4.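

Going by these compounds alone, at the triple-bonded carbon, the exchange of pyridin-3-yl for 3-(trifluoromethyl)phenyl is the first change in this assay to move the number beyond the scatter, with a 2.9-fold higher number from compound 3 to compound 4 (0.46 log units; beyond the scatter), so one six-membered aromatic ring in place of another is enough to register at this position. The same group also stands apart from both saturated chains, with a 4.3-fold higher number from compound 2 to compound 4 (0.63 log units; beyond the scatter) and a 5.6-fold higher number from compound 1 to compound 4 (0.75 log units; beyond the scatter), which leaves compound 4 alone at the high end of the series, although all three steps are modest. The exchange removes the ring nitrogen and brings in trifluoromethyl in a single step, and nothing at hand explains the rise.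

Still open, on these data alone, is whether the rise goes with the trifluoromethyl group or with the loss of the ring nitrogen; a plain phenyl on the triple-bonded carbon would separate the two. Also open, as far as these compounds go, is how a chloro or methoxy group on that phenyl ring, or an amine at the end of a saturated chain, would read in this assay.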